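The source may report more compounds than this note shows. Statements on the series, on what has been measured and on what is new or still open speak of the compounds shown alone.

Compound 1 `Clc1cccc(Nc2ncnc3ccc(NCc4ncc5ccccc5n4)cc23)c1` gives 5650 nM in a functional assay on HepG2 cells (Homo sapiens) for antiproliferative activity, read by MTT assay, with a stated time of 48 h; on this read-out higher numbers stand for weaker inhibition and lower numbers for stronger inhibition. For the measured compounds named here, compound 2 `Cc1cccc(CNc2ccc3ncnc(Nc4cccc(Cl)c4)c3c2)n1` gives 3630 nM in this assay, and the one step recorded so far, a 1.6-fold lower number from compound 1 to compound 2 (0.19 log units; within the scatter), does not separate the two compounds. Compound 2 thus holds the smaller of the two numbers, with no separation beyond the scatter from compound 1.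

Compound 3 `O=C(/C=C/c1cccs1)Nc1ccc2ncnc(Nc3cccc(Cl)c3)c2c1` differs from compound 2 by (2-(thiophen-2-yl)ethenyl)carbonyl in place of (6-methylpyridin-2-yl)methyl on a nitrogen on an aromatic ring. Going by the values given here, the single measured step exchanged one aromatic ring for another on the same saturated chain carbon and stayed within the scatter; it says nothing about removing that chain carbon and putting an unsaturated amide in its place, so no measured step bears directly on this change and no direction can be drawn from the data. Compound 3 is therefore expected to land near compound 2, at an estimated 3500 nM with a range from 1000 nM to 12000 nM. The step of a 1.0-fold lower number from compound 2 to compound 3 (0.02 log units; within the scatter) that this estimate means is expected to stay within the scatter, with the wide range reflecting the absence of any comparable measured step.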

Compound 3, half-maximal inhibitory concentration: 10400 nM
The estimate for compound 3 lay 3.0-fold (0.47 log units) below the measured number, and the stated range covers the measured number.
By their numbers in this assay, from the lowest: compounds 2, 1 and 3 (each within the scatter of the next, the first and the last beyond it).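

In this assay the substituent on a nitrogen on an aromatic ring can move the number beyond the scatter: (2-(thiophen-2-yl)ethenyl)carbonyl in place of (6-methylpyridin-2-yl)methyl gives a modest rise (a 2.9-fold higher number from compound 2 to compound 3 (0.46 log units; beyond the scatter)), whereas the earlier exchange of one aromatic ring for another on the saturated chain carbon (a 1.6-fold lower number from compound 1 to compound 2 (0.19 log units; within the scatter)) did not separate its pair. For the compounds shown here, this change alters several features at once, replacing the saturated chain carbon with a carbonyl, exchanging a six-membered aromatic ring with 1 hetero atom for a five-membered aromatic ring with 1 hetero atom, and adding 2 double bonds outside aromatic rings, so the single step cannot assign the shift to any one of them. No measurement at hand accounts for the shift.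

A (thiophen-2-yl)methyl group on the same nitrogen would separate the effect of the ring from that of the carbonyl and the ethenyl link. Likewise, a 3-(thiophen-2-yl)propanoyl group would show whether the number depends on the double bond in the chain or on the carbonyl alone.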